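This account rests on a few compounds, and the source may have more. Where it says the series, first, only, none or still open, it means among the compounds named here.

Of the compounds shown here, two from this series have been tested in a functional assay on the whole organism (strain albino) for inhibition, with Rattus norvegicus as the target, read by paw edema, with stated times of 1 h and 4 h, at a dose of 200 mg/kg by the oral route; on this read-out lower numbers stand for less inhibition and higher numbers for more inhibition at the one dose given (going by the name of the read-out). Compound 1, `O=c1oc2ccccc2cc1C1=NN(c2ccccc2)[C@@H](c2ccc(Cl)cc2Cl)C1`, gives 67.5%. Compound 2, `O=c1oc2ccccc2cc1C1=NN(c2ccccc2)[C@@H](c2cccc([N+](=O)[O-])c2)C1`, gives 31.2%, the lower of the two numbers. Within the data shown here, the one measured step, a number 36.3 percentage points lower from compound 1 to compound 2 (beyond the scatter), shows that swapping the group on the saturated ring carbon can move the read-out a long way.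

Compound 3, `COc1cccc([C@H]2CC(c3cc4ccccc4oc3=O)=NN2c2ccccc2)c1`, differs from compound 2 only in that (methoxy in place of nitro on an aromatic carbon). Among the measured compounds shown here, no measured pair shows this particular exchange, so the step from compound 1 to compound 2 is the only guide, and it tells merely that the aryl group matters, not how methoxy compares with nitro. The expected step is therefore a moderate rise, a number 13.8 percentage points higher from compound 2 to compound 3 (beyond the scatter), with wide uncertainty. Compound 3 is estimated at 45% in this assay, within a range from 25% to 65%.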

Compound 3, a percentage reported as inhibition, in the whole organism at one dose (the size of the read-out at that dose, not a potency): 61.5%
Estimate against measurement, compound 3: 16.5 percentage points below, within the range that was stated.
By their numbers in this assay, from the lowest: compound 2; then compounds 3 and 1 (each within the scatter of the next).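

Keeping the aryl group and changing only the single group on it, at the same place, matters a great deal in this assay: methoxy in place of nitro gives a number 30.3 percentage points higher from compound 2 to compound 3 (beyond the scatter), so the earlier large step need not depend on replacing the whole aryl group. The 3-methoxyphenyl and 2,4-dichlorophenyl groups, though different in their substituents, give a number 6 percentage points lower from compound 1 to compound 3 (within the scatter), so compound 2 is the low one of the three, and a high number does not require the chlorines. Nothing available gives a reason for the gap between nitro and methoxy.

Going by these compounds, whether an amino or hydroxyl group at this place would sit nearer compound 2 or compound 3 remains open. So does whether methoxy would keep its number elsewhere on the ring, or whether a longer chain such as ethoxy would.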